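Sulfonylpiperazine side chains and adenosine A3 receptor displacement

The compounds below may be only part of what the source reports. "The series", "measured", "known", "first", "only" and "open" are said of these compounds alone.

Compound 1 `CCCn1c(=O)[nH]c2nc(-c3ccc(S(=O)(=O)N4CCN(Cc5cccc(Br)c5)CC4)cc3)[nH]c2c1=O` gives 23% in an assay on CHO cells for displacement of a labelled ligand from adenosine receptor A3 (Homo sapiens), read by scintillation counting, with a stated time of 45 min, tested at 1 uM, in the presence of a further agent that is not named here; on this read-out lower numbers stand for less inhibition and higher numbers for more inhibition at the one concentration tested (going by the name of the read-out).
Compound 2 `CCCn1c(=O)[nH]c2nc(-c3ccc(S(=O)(=O)N4CCN(c5ccccc5Br)CC4)cc3)[nH]c2c1=O` gives 20% in this assay.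

Within the data shown here, compound 2 stands as the lowest of the two numbers measured so far, though its only neighbour, compound 1, sits only a number 3 percentage points lower from compound 1 to compound 2 (within the scatter) away, so the two cannot be told apart on this read-out. Among the measured compounds shown here, the one measured step, a number 3 percentage points lower from compound 1 to compound 2 (within the scatter), swaps a 3-bromobenzyl group for a 2-bromophenyl group on an amine nitrogen in a ring and leaves the displacement essentially unchanged.

Compound 3 `CCCn1c(=O)[nH]c2nc(-c3ccc(S(=O)(=O)N4CCN(C(C)c5ccccc5)CC4)cc3)[nH]c2c1=O` is the next member. It differs from compound 2 by 1-phenylethyl in place of 2-bromophenyl on an amine nitrogen in a ring. For the measured compounds named here, the only comparable step on record, a number 3 percentage points lower from compound 1 to compound 2 (within the scatter), changed a group on the same ring nitrogen without moving the number beyond the scatter. With that single reference, the change from compound 2 to compound 3 is expected to leave the displacement in the same low band, a step of about a number 2 percentage points higher from compound 2 to compound 3 (within the scatter). Compound 3 is therefore estimated at 22% in this assay, with a range from 8% to 38%.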

Compound 3, a percentage reported as inhibition, at one concentration (the size of the read-out at that concentration, not a potency): 0%
Estimate against measurement, compound 3: 22 percentage points above; the measured number lies below the stated range.
By their numbers in this assay, from the lowest: compound 3; then compounds 2 and 1 (each within the scatter of the next).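

Compound 1 and compound 2 suggested that the group on this amine nitrogen in a ring could be exchanged freely in this assay, but 1-phenylethyl shows that the position does respond, with a number 20 percentage points lower from compound 2 to compound 3 (beyond the scatter) and a number 23 percentage points lower from compound 1 to compound 3 (beyond the scatter). With both steps beyond the scatter, compound 3 at 0% clearly stands lowest of the three, while the other two remain indistinguishable. All three groups carry one six-membered aromatic ring of carbon only, so having that ring on the nitrogen is not enough to hold the number in the low band seen for compound 1 and compound 2, and nothing available here explains the drop.

The 1-phenylethyl group carries no bromine, whereas the groups it replaces both do, so these compounds cannot separate the loss of bromine from the change in how the ring is joined to the nitrogen. A plain benzyl group on the same nitrogen would help to pull those two apart, and a 1-(3-bromophenyl)ethyl group would test whether bromine can restore the number.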